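The source may hold more compounds than are shown below. What is called first, only, known or untested is meant among the compounds shown, and "the series" means these compounds.

Compound 1 `O=C(NCc1cc(Cl)ccc1-n1cnnn1)[C@@H]1C[C@@H]2C[C@@H]2N1C(=O)[C@H](O)c1ccccc1F`: in an ADME assay on liver for metabolic stability, with Liver microsome (Homo sapiens) as the target, read by LC-MS, using microsomes (on this read-out lower numbers stand for slow clearance and higher numbers for fast clearance), compound 1 gives only a limit of the assay, < 12 mL.min-1.g-1.
Compound 2 `CC(C)(C)OC[C@@H](O)C(=O)N1[C@H](C(=O)NCc2cc(Cl)ccc2-n2cnnn2)C[C@@H]2C[C@@H]21`: in this assay compound 2 gives 21 mL.min-1.g-1.
Compound 3 `O=C(NCc1cc(Cl)ccc1-n1cnnn1)[C@@H]1C[C@@H]2C[C@@H]2N1C(=O)[C@H](O)Cn1cccn1`: in this assay compound 3 gives only a limit, < 12 mL.min-1.g-1.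

Compound 3 therefore stands at the floor of the read-out, a place shared by two of the three measured values (the limit of < 12 mL.min-1.g-1 in this assay, at which 2 of the 3 values shown sit). Compound 4 `CC(C)(C)[C@@H](O)C(=O)N1[C@H](C(=O)NCc2cc(Cl)ccc2-n2cnnn2)C[C@@H]2C[C@@H]21` changes one group: tert-butyl in place of (1H-pyrazol-1-yl)methyl on a saturated chain carbon bound to a carbonyl carbon and an oxygen on a saturated carbon. Going by the values given here, two measured steps touch this position. One is an at least 1.7-fold lower number from compound 2 to compound 3 (0.24 log units; that floor lies within the scatter), which swaps tert-butoxy for 1H-pyrazol-1-yl and stays within the scatter. The other, a step that the two limits leave unreadable from compound 1 to compound 3, cannot be read. Among the compounds with values here, no measured step carries tert-butyl itself. The expected step is then an at least 1.3-fold higher number from compound 3 to compound 4 (0.12 log units; that floor lies within the scatter), modest and upward. Compound 4 is estimated at 16 mL.min-1.g-1, within 8 mL.min-1.g-1 to 32 mL.min-1.g-1.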

Compound 4, intrinsic clearance in microsomes: 75 mL.min-1.g-1
Estimate against measurement, compound 4: 4.7-fold (0.67 log units) below; the whole stated range lies below it.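

At this place, on a saturated chain carbon, compound 4 with its tert-butyl has the highest number of the compounds shown in this assay, with an at least 6.2-fold higher number from compound 3 to compound 4 (0.79 log units; beyond the scatter) and an at least 6.2-fold higher number from compound 1 to compound 4 (0.79 log units; beyond the scatter). Against (tert-butoxy)methyl there is a 3.6-fold higher number from compound 2 to compound 4 (0.55 log units; beyond the scatter), so a change at this place can move the number beyond the scatter, which no earlier step had shown. The steps starting from compound 1 and compound 3 give only a floor, since both of those compounds sit at a limit: the limit of < 12 mL.min-1.g-1 in this assay, at which 2 of the 4 values shown sit.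

From the compounds shown here alone, whether an isopropyl or a methyl group at this place would also give such a high number stays open. So does what an amine there would give.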